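The compounds below may be only part of what the source reports. "The series", "measured", "known", "first", "only" and "open" are said of these compounds alone.

Measured so far: compound 1 `O=C(O)CCN1Cc2ccc(NC(=O)c3ccc4c(c3)CNCC4)cc2C1=O` with 1100 nM in a functional assay on a cell-free system (Platelet, plasma, Homo sapiens) for inhibition (on this read-out higher numbers stand for weaker inhibition and lower numbers for stronger inhibition), and compound 2 `CC(CC(=O)O)N1Cc2ccc(NC(=O)CC3CCNCC3)cc2C1=O` with 2700 nM in this assay.

Compound 2 has the highest number of the two in this assay; compound 1 sits lower, and the gap between them lies beyond the scatter. Compound 3 `CC(CC(=O)O)N1Cc2ccc(NC(=O)CCCC3CCNCC3)cc2C1=O` is not yet measured. It differs from compound 2 by 2-(piperidin-4-yl)ethyl in place of piperidin-4-yl on a saturated chain carbon bound to a carbonyl carbon. Among the measured compounds shown here, no measured step of this kind is available, so the expectation for compound 3 rests on compound 2 alone. Compound 3 is expected to show a step of a 1.1-fold lower number from compound 2 to compound 3 (0.03 log units; within the scatter), within the scatter. The estimated value of compound 3 in this assay is 2500 nM, in a range from 800 nM to 8000 nM.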

Compound 3, half-maximal inhibitory concentration: 5400 nM
For compound 3 the middle estimate is 2.2-fold (0.33 log units) below the measured one; the range from low to high includes it.
By their numbers in this assay, from the lowest: compound 1; then compounds 2 and 3 (each within the scatter of the next).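

In this assay, 2-(piperidin-4-yl)ethyl in place of piperidin-4-yl on a saturated chain carbon bound to a carbonyl carbon gives a 2.0-fold higher number from compound 2 to compound 3 (0.30 log units; within the scatter), so this position accepts the longer chain without a step beyond the scatter. This single step cannot establish a trend with chain length. No measured finding explains the result.

From the compounds shown here alone, whether a longer chain ending in piperidin-4-yl, or an aminomethyl group in its place, would behave alike remains open. Compound 1 differs from compound 2 and compound 3 in more than one place, so it cannot settle this.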